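Amide variation on the shared core: working notes

The compounds below may be only part of what the source reports. "The series", "measured", "known", "first", "only" and "open" are said of these compounds alone.

Measured compounds:
compound 1 `CCCn1c(NC(=O)c2ccnn2CC)nc2cc(C(N)=O)cc(OC)c21` gives > 100000 nM in an assay for activation of interferon regulatory factor 3 (Homo sapiens), read by a luciferase reporter, with a stated time of 20 h; on this read-out higher numbers stand for an effect only at larger amounts of compound and lower numbers for an effect already at smaller amounts
compound 2 `COc1cc(C(N)=O)cc2nc(NC(=O)c3ccc4ccccc4n3)n(CCCNC(=O)OCc3ccccc3)c12` gives > 100000 nM in this assay
compound 3 `CCn1nccc1C(=O)Nc1nc2cc(C(N)=O)cc(OC)c2n1CCCNC(=O)OCc1ccccc1` gives > 100000 nM in this assay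

Each of these three values is a limit of this assay and not a number. For compound 3 the reading is therefore only a limit, > 100000 nM. The two measured steps that lead to compound 3, a step that the two limits leave unreadable from compound 1 to compound 3 and a step that the two limits leave unreadable from compound 2 to compound 3, cannot be read in size or direction, because every value shown sits at the limit of > 100000 nM in this assay, at which 3 of the 3 values shown sit.

Compound 4 `COc1cc(C(N)=O)cc2nc(NC(=O)CCc3ccccc3)n(CCCNC(=O)OCc3ccccc3)c12` differs from compound 3 in one place: phenethyl in place of 1-ethyl-1H-pyrazol-5-yl on a carbonyl carbon. For the measured compounds named here, no measured step bears on this change with a readable size, so there is no basis for expecting either a gain or a loss beyond the scatter. Compound 4 is therefore expected to remain at the limit as well, with an estimate of 100000 nM (range 30000 nM to 300000 nM). The step this estimate means, a number no higher from compound 3 to compound 4 (the limit leaves the size open), is expected to be none beyond the scatter.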

Compound 4, half-maximal effective concentration: > 100000 nM
Compound 4: a limit, no number; the forecaster's own chance of this, stated with the estimate: 80%; the middle value sits exactly at the limit.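

In this assay compound 4 gives > 100000 nM as a limit and not a number, so the steps to compound 4 from compound 3 and from compound 2 cannot be read: the limit of > 100000 nM in this assay, at which 4 of the 4 values shown sit.

The compounds shown leave open whether any amide group on the shared core gives a readable value.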